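Nitro for cyano on the amide aryl ring

This account rests on a few compounds, and the source may have more. Where it says the series, first, only, none or still open, it means among the compounds named here.

Measured in a functional assay on MDA-MB-231 cells (Homo sapiens) for antiproliferative activity, read by CCK-8 assay, with a stated time of 72 h; on this read-out higher numbers stand for weaker inhibition and lower numbers for stronger inhibition:
compound 1 `Cc1cccc(C(=O)Nc2cccc(-c3oc4cc(-c5ccc(F)cc5)ccc4c(=O)c3O)c2)c1` gives 2840 nM
compound 2 `COc1cc(OC)cc(C(=O)Nc2cccc(-c3oc4cc(-c5ccc(F)cc5)ccc4c(=O)c3O)c2)c1` gives 4040 nM
compound 3 `N#Cc1ccc(C(=O)Nc2cccc(-c3oc4cc(-c5ccc(F)cc5)ccc4c(=O)c3O)c2)cc1` gives 11600 nM

Compound 3 stands at the high end of the three numbers in this assay: a 4.1-fold higher number from compound 1 to compound 3 (0.61 log units; beyond the scatter) and a 2.9-fold higher number from compound 2 to compound 3 (0.46 log units; beyond the scatter) are both beyond the scatter, while a 1.4-fold higher number from compound 1 to compound 2 (0.15 log units; within the scatter) is within it. Compound 4 `O=C(Nc1cccc(-c2oc3cc(-c4ccc(F)cc4)ccc3c(=O)c2O)c1)c1ccc([N+](=O)[O-])cc1` has not yet been measured; it differs from compound 3 by nitro in place of cyano on an aromatic carbon. The measured steps each exchange the whole aryl group on the carbonyl carbon; none exchanges one group for another at a single aromatic carbon of that ring. They bear on the present change only in showing that the 4-cyanophenyl compound sits at the high end, with the two steps to it modest in size. Without a direct precedent, no step beyond the scatter is expected in this assay, and a 1.1-fold lower number from compound 3 to compound 4 (0.02 log units; within the scatter) is the expected outcome for compound 4. Compound 4 is estimated at 11000 nM, with a range from 4000 nM to 30000 nM.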

Compound 4, half-maximal inhibitory concentration: 14700 nM
For compound 4 the middle estimate is 1.3-fold (0.13 log units) below the measured one; measured number inside the range.
By their numbers in this assay, from the lowest: compounds 1 and 2 (each within the scatter of the next); then compounds 3 and 4 (each within the scatter of the next).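

In this assay, nitro in place of cyano on this aromatic carbon, para to a large group, gives a 1.3-fold higher number from compound 3 to compound 4 (0.10 log units; within the scatter), so the two groups are not separated at this position. The 4-nitrophenyl amide shares the high end with the 4-cyanophenyl amide, with a 3.6-fold higher number from compound 2 to compound 4 (0.56 log units; beyond the scatter) and a 5.2-fold higher number from compound 1 to compound 4 (0.71 log units; beyond the scatter), so compound 3 and compound 4 together stand apart from compound 1 and compound 2. Nothing measured here accounts for this shared level.

As far as these compounds go, whether an amine or a carboxylic acid on the same aromatic carbon would stay at this level remains open. Also open, from the compounds shown here alone, is whether the gap to compound 1 and compound 2 follows from the groups themselves or from where they sit on the ring, since those compounds differ from compound 3 and compound 4 in both.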